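The compounds below may be only part of what the source reports. "The series", "measured", "known", "first", "only" and "open" are said of these compounds alone.

Measured so far in a functional assay on BJAB cells (Homo sapiens) for antiproliferative activity, with a stated time of 4 days; a lower number here means that less compound is needed, a higher number that more compound is needed for the effect:
compound 1 `COc1cc(-c2c(C)nn(-c3nc(-c4ccc(Cl)c(Cl)c4)c(SC(C)C)s3)c2C(=O)O)cc(C(F)(F)F)c1` — 1380 nM
compound 2 `Cc1nn(-c2nc(-c3ccc(Cl)c(Cl)c3)c(SC(C)C)s2)c(C(=O)O)c1-c1cccc(F)c1` — 900 nM
compound 3 `Cc1cc(C)cc(-c2c(C)nn(-c3nc(-c4ccc(Cl)c(Cl)c4)c(SC(C)C)s3)c2C(=O)O)c1` — 2700 nM

All three share one core and differ only in the aryl group on the five-membered ring. The step of a 1.5-fold lower number from compound 1 to compound 2 (0.19 log units; within the scatter) lies within the scatter, as does a 2.0-fold higher number from compound 1 to compound 3 (0.29 log units; within the scatter); only a 3.0-fold higher number from compound 2 to compound 3 (0.48 log units; beyond the scatter) is a modest step beyond it, so compound 3 stands at the upper end of this small set, separated clearly only from compound 2.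

Compound 4 `Cc1nn(-c2nc(-c3ccc(Cl)c(Cl)c3)c(SC(C)C)s2)c(C(=O)O)c1-c1cnn(C)c1` carries the change (1-methyl-1H-pyrazol-4-yl in place of 3,5-dimethylphenyl on an aromatic carbon). The two steps that bear on it are those at the same position, a 2.0-fold higher number from compound 1 to compound 3 (0.29 log units; within the scatter) and a 3.0-fold higher number from compound 2 to compound 3 (0.48 log units; beyond the scatter): swapping one aryl group for another has moved this assay by a modest amount at most. Among the compounds with values here, no measured step exchanges a six-membered carbon ring for a five-membered ring with two nitrogens, so the direction is uncertain. The expectation for compound 4 is a small step, a 1.8-fold lower number from compound 3 to compound 4 (0.26 log units; within the scatter), toward a somewhat lower number, since the smaller aryl group in compound 2 gave 900 nM. The estimate for compound 4 is 1500 nM, with a range from 500 nM to 4500 nM.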

Compound 4, half-maximal effective concentration: 6800 nM
Beside the measured number, compound 4's estimate is 4.5-fold (0.66 log units) below it, outside the stated range (above it).
By their numbers in this assay, from the lowest: compounds 2, 1 and 3 (each within the scatter of the next, the first and the last beyond it); then compound 4.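

In this assay, within the data shown here, 1-methyl-1H-pyrazol-4-yl on this aromatic carbon is the first group at this position to set one compound apart from all the others, with a 2.5-fold higher number from compound 3 to compound 4 (0.40 log units; beyond the scatter) and a 4.9-fold higher number from compound 1 to compound 4 (0.69 log units; beyond the scatter) and, as the largest of the three, a 7.6-fold higher number from compound 2 to compound 4 (0.88 log units; beyond the scatter) in the same direction. The three substituted phenyl groups thus stand together at the lower end, each within the scatter of the next, although compound 2 and compound 3 are separated beyond it, while the five-membered aromatic ring with 2 hetero atoms stands alone at the upper end, and its 6 heavy atoms against the 8 of 3,5-dimethylphenyl did not bring a lower number. No measurement at hand accounts for this rise.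

The compounds shown leave open whether 1H-pyrazol-4-yl without the methyl, a pyridin-3-yl ring or a phenyl ring carrying an amine would fall with the phenyl compounds or with compound 4. They also leave open whether the same exchange would move the number as far with an ester or an amide in place of the carboxy group.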